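Swapping an amine for a sulfonate ester on a fused core

This account rests on a few compounds, and the source may have more. Where it says the series, first, only, none or still open, it means among the compounds named here.

Measured compounds:
compound 1, `C[C@@H](Nc1c(C(=O)NCc2ccc(F)cc2)nc(Br)c2cccnc12)c1ccccc1`: > 20000 nM
compound 2, `N[C@H]1CC[C@H](Nc2c(C(=O)NCc3ccc(Oc4ccccc4)cc3)nc(Br)c3cccnc23)CC1`: 4000 nM
compound 3, `COc1cccc(CNC(=O)c2nc(Br)c3cccnc3c2N[C@H]2CC[C@H](N)CC2)c1`: 7000 nM

Compound 1 stands at the weak end of what has been measured in a functional assay on MDA-MB-435 cells (Homo sapiens) for cytotoxicity, read by MTT assay, with a stated time of 72 h; a higher number here means a weaker inhibitor, a lower number a stronger inhibitor. For compound 1 the assay reports no number, only a limit, > 20000 nM. Compound 2 gives 4000 nM in this assay, and compound 3 gives 7000 nM, both as real numbers rather than limits.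

Compound 4, `Cc1ccc(S(=O)(=O)Oc2c(C(=O)NCc3ccc(F)cc3)nc(Br)c3cccnc23)cc1`, is not yet measured. It differs from compound 1 in a single place: ((4-methylphenyl)sulfonyl)oxy in place of (1-phenylethyl)amino on an aromatic carbon. Compound 1 is known only as a limit, so the step from compound 1 to compound 4 cannot be measured against a fixed starting number; only the question of whether compound 4 falls inside the measurable range or sits at the limit as well can be answered. No measured step between the compounds shown exists to guide that question. The expectation is that the change brings compound 4 no clearly measurable gain, and that the step that the limit leaves unreadable from compound 1 to compound 4 is estimated to stay within the scatter. Compound 4 is therefore expected to give about 25000 nM in this assay, with a likely range from 8000 nM to 80000 nM.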

Compound 4, half-maximal inhibitory concentration: > 20000 nM
Compound 4: no number, only a limit; the forecaster's own chance of this, stated with the estimate: 70%; the middle value does not contradict the limit.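

In this assay compound 4 gives no number, only a limit, > 20000 nM. Going by these compounds alone, compound 1 is likewise known only as a limit, so no step between compound 1 and compound 4 can be read. The compounds shown leave open whether ((4-methylphenyl)sulfonyl)oxy or (1-phenylethyl)amino on this aromatic carbon gives the stronger inhibitor.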